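The source may hold more compounds than are shown below. What is called first, only, known or untested is meant among the compounds shown, and "the series" means these compounds.

Series notes. Compound 1 `Cc1cccc(NC(=O)Nc2cccc(CNc3ncnc4ccccc34)c2)c1` carries, on the amide-type nitrogen of its urea, a 3-methylphenyl; in a functional assay on A549 cells (Homo sapiens) for antiproliferative activity, read by MTT assay (on this read-out lower numbers stand for stronger inhibition and higher numbers for weaker inhibition), compound 1 gives 30200 nM. Compound 2 `Cc1ccc(NC(=O)Nc2cccc(CNc3ncnc4ccccc34)c2)cc1` gives 24900 nM and compound 3 `COc1ccc(NC(=O)Nc2cccc(CNc3ncnc4ccccc34)c2)cc1` gives 29300 nM in this assay. Among the three numbers compound 3 stands second highest, with compound 1 nearest and compound 2 furthest, and all three lie within the scatter of one another. The measured steps are a 1.2-fold lower number from compound 1 to compound 2 (0.08 log units; within the scatter), a 1.0-fold lower number from compound 1 to compound 3 (0.01 log units; within the scatter) and a 1.2-fold higher number from compound 2 to compound 3 (0.07 log units; within the scatter); each exchanges one substituted phenyl on the amide-type nitrogen for another, and none moves the number beyond the scatter.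

Compound 4 `O=C(Nc1cccc(CNc2ncnc3ccccc23)c1)Nc1ccccc1F` continues the same kind of exchange: 2-fluorophenyl in place of 4-methoxyphenyl on an amide-type nitrogen. Going by the values given here, no measured step brings a fluorine onto this phenyl, so the three within-scatter aryl swaps are the only guide. From them no movement beyond the scatter is expected in this assay, and the change from compound 3 to compound 4 is estimated as a 1.0-fold lower number from compound 3 to compound 4 (0.02 log units; within the scatter). Compound 4 is therefore expected to give about 28000 nM in this assay, within 12000 nM to 65000 nM.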

Compound 4, half-maximal inhibitory concentration: 26100 nM
The estimate for compound 4 lay 1.1-fold (0.03 log units) above the measured number; measured number inside the range.
By their numbers in this assay, from the lowest: compounds 2, 4, 3 and 1 (each within the scatter of the next).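

In this assay the exchange brings the first fluorine onto this phenyl, yet the new steps all stay within the scatter: a 1.1-fold lower number from compound 3 to compound 4 (0.05 log units; within the scatter) and a 1.0-fold higher number from compound 2 to compound 4 (0.02 log units; within the scatter) and a 1.2-fold lower number from compound 1 to compound 4 (0.06 log units; within the scatter). Earlier steps covered only methyl and methoxy on the phenyl at this amide-type nitrogen; 2-fluorophenyl extends the tolerated set to a halogen-bearing ring and to a group with no hydrogen-bond acceptor counted, and all four compounds remain within the scatter of one another. No supporting measurement accompanies this result.

From the compounds shown here alone, whether any replacement at this nitrogen moves the number beyond the scatter stays open, for example an amine or a carboxylic acid on the phenyl, or a longer chain in its place. Also open, going by these compounds, is how 3-fluorophenyl or 4-fluorophenyl would compare with 2-fluorophenyl.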